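This account rests on a few compounds, and the source may have more. Where it says the series, first, only, none or still open, it means among the compounds named here.

In an ADME assay on microsomes from liver (Homo sapiens) for metabolic stability, read by LC-MS, with a stated time of 10 min (a lower number here means that less of the compound is left, a higher number that more of the compound is left), compound 2 `c1cnc2c(c1)CCC[C@@H]2N(CC1CC1)C[C@H]1Cc2c(cccc2N2CCNCC2)CN1` gives 82.1%, the lowest of the three numbers in hand; compound 1 `CCCN(C[C@H]1Cc2c(cccc2N2CCNCC2)CN1)[C@H]1CCCc2cccnc21` gives 100% and compound 3 `CN(C[C@@H]1Cc2c(cccc2N2CCNCC2)CN1)[C@H]1CCCc2cccnc21` gives 94.2%, each beyond the scatter above compound 2. Compound 4 `CN(C[C@H]1Cc2c(cccc2N2CCNCC2)CN1)[C@H]1CCCc2cccnc21` differs from compound 2 by hydrogen in place of cyclopropyl on a saturated chain carbon bound to an amine nitrogen. Among the compounds with values here, the one measured step that bears on this change is a number 17.9 percentage points lower from compound 1 to compound 2 (beyond the scatter), a modest loss when the cyclopropyl comes in. Taking the cyclopropyl away again is therefore expected to give a gain of comparable size in this assay, bringing compound 4 back toward the level shown by compound 1 and compound 3. The estimate for compound 4 is 95%, within 84% to 100%, an expected step of a number 12.9 percentage points higher from compound 2 to compound 4 (beyond the scatter).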

Compound 4, percent of the compound remaining: 99.7%
Beside the measured number, compound 4's estimate is 4.7 percentage points below it; the range from low to high includes it.
By their numbers in this assay, from the lowest: compound 2; then compounds 3, 4 and 1 (each within the scatter of the next).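

In this assay, hydrogen in place of cyclopropyl recovers the loss seen with that group (a number 17.6 percentage points higher from compound 2 to compound 4 (beyond the scatter)), so the lower number follows the cyclopropyl in the compounds shown. Hydrogen in place of ethyl leaves no step beyond the scatter (a number 0.3 percentage points lower from compound 1 to compound 4 (within the scatter)), so among these compounds only cyclopropyl stands apart at this position. The stereocentre also gives no step beyond the scatter (a number 5.5 percentage points higher from compound 3 to compound 4 (within the scatter)), a reading that rests on a clean comparison: the fact that compounds 3 and 4 differ only in the configuration as drawn.

As far as these compounds go, whether a longer chain or a carboxylic acid at this position would hold the number stays open. Also open, from the compounds shown here alone, is whether configuration matters once cyclopropyl is present.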